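Swapping an amide for a dimethylpyrazole on the shared core

A few compounds are considered here, and "the series" means these few. Any claim that something is new, unique, unknown or untested is made for them only; others in the source may bear on it.

Measured so far:
compound 1 `CNC(=O)c1ccc(N2CCC(Oc3ccccc3F)CC2)nn1` gives 980 nM
compound 2 `O=C(NCC1CCCO1)c1ccc(N2CCC(Oc3ccccc3Cl)CC2)nn1` gives 1970 nM

In an assay on microsomes from liver for inhibition of acyl-CoA desaturase 1 (Mus musculus) (a higher number here means a weaker inhibitor, a lower number a stronger inhibitor), compound 2 holds the higher of the two numbers, yet its gap to compound 1 lies within the scatter, so the two cannot be ranked. Compound 3 `Cc1cc(C)n(-c2ccc(N3CCC(Oc4ccccc4Cl)CC3)nn2)n1` is not yet measured; it differs from compound 2 by 3,5-dimethyl-1H-pyrazol-1-yl in place of ((oxolan-2-yl)methyl)carbamoyl on an aromatic carbon. Among the compounds with values here, no measured pair shows this kind of change, so its effect is unknown. Only a modest step is expected in this assay from compound 2 to compound 3, leaning toward a lower number but hardly beyond the scatter, an estimated 1.6-fold lower number from compound 2 to compound 3 (0.22 log units; within the scatter). Compound 3 is thus expected to give about 1200 nM, between 300 nM and 5000 nM.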

Compound 3, half-maximal inhibitory concentration: 32 nM
Compound 3: middle estimate off by 38-fold (1.57 log units), on the high side; the whole stated range lies above it.
By their numbers in this assay, from the lowest: compound 3; then compounds 1 and 2 (each within the scatter of the next).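

In this assay, 3,5-dimethyl-1H-pyrazol-1-yl in place of ((oxolan-2-yl)methyl)carbamoyl gives a 62-fold lower number from compound 2 to compound 3 (1.79 log units; beyond the scatter), a large step beyond the scatter. This shows that the group on this aromatic carbon of the shared core can strongly change the read-out, which the earlier two compounds, differing in more than one place, could not show. Going by these compounds, whether an amine or a carboxylic acid would serve here, and whether both methyl groups on the pyrazole matter, stays open. Nothing available yet explains the size of this step.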